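The source may hold more compounds than are shown below. What is called first, only, known or untested is meant among the compounds shown, and "the series" means these compounds.

Compound 1 `Cc1nc(-c2ccccc2F)c(C(=O)N2CCN(c3cc(Cl)cc(Cl)c3)CC2)o1` is the starting point of this step. In a functional assay on HCT-116 cells (Homo sapiens) for inhibition, read by MTT assay, with a stated time of 72 h (on this read-out higher numbers stand for weaker inhibition and lower numbers for stronger inhibition), compound 1 gives 319 nM, the lowest of the three numbers available, though neither of the other two lies beyond the scatter of it. Compound 3 `Cc1nc(-c2cccc(F)c2)c(C(=O)N2CCN(c3cc(Cl)cc(Cl)c3)CC2)o1` gives 366 nM, and compound 2 `COc1cc(OC)cc(N2CCN(C(=O)c3oc(C)nc3-c3ccc(F)cc3)CC2)c1`, which carries a 4-fluorophenyl group on a core that differs elsewhere, gives 404 nM.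

The unmeasured compound 4 `Cc1nc(-c2ccc(F)cc2)c(C(=O)N2CCN(c3cc(Cl)cc(Cl)c3)CC2)o1` differs from compound 1 only in where the fluorine sits on the phenyl ring: 4-fluorophenyl in place of 2-fluorophenyl on an aromatic carbon.

One measured step speaks directly to this kind of change. Moving the fluorine from 2-fluorophenyl to 3-fluorophenyl gave a 1.1-fold higher number from compound 1 to compound 3 (0.06 log units; within the scatter). The value of compound 2, the only measured bearer of a 4-fluorophenyl group, is also within the scatter of compound 1. Nothing here points to a step beyond the scatter in either direction.

Compound 4 is therefore expected to give about 340 nM in this assay, within a range of 170 nM to 700 nM. The step from compound 1 is estimated as a 1.1-fold higher number from compound 1 to compound 4 (0.03 log units; within the scatter), a change that would not stand out from repeated measurement.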

Compound 4, half-maximal inhibitory concentration: 484 nM
Compound 4: the middle estimate sits 1.4-fold (0.15 log units) below what was measured; the range from low to high includes it.
By their numbers in this assay, from the lowest: compounds 1, 3, 2 and 4 (each within the scatter of the next).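

With compound 4, the 2-fluorophenyl, 3-fluorophenyl and 4-fluorophenyl groups can all be compared on the same core in this assay. Placing the fluorine at the far end of the ring gives the largest step read so far at this position (a 1.5-fold higher number from compound 1 to compound 4 (0.18 log units; within the scatter)), yet neither this step nor the one between the other two fluorophenyl compounds (a 1.3-fold higher number from compound 3 to compound 4 (0.12 log units; within the scatter)) separates the groups, so the three placements cannot be told apart here. Going by these compounds alone, compound 4 also gives the first comparison on the amine nitrogen in a ring, where 3,5-dichlorophenyl and 3,5-dimethoxyphenyl cannot be told apart with 4-fluorophenyl in place (a 1.2-fold higher number from compound 2 to compound 4 (0.08 log units; within the scatter)). No measurement at hand offers an explanation for these small differences.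

The compounds shown leave open whether anything other than a single fluorine on this phenyl ring, such as a methoxy group, a chlorine or a nitrile, would move the number beyond the scatter. They also leave open whether a carboxylic acid or an amine on the aryl group at the ring nitrogen would do so.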